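The compounds below may be only part of what the source reports. "The series", "measured", "known", "first", "only" and "open" are said of these compounds alone.

Measured compounds, with their values in a functional assay on SK-BR-3 cells (Homo sapiens) for cytotoxicity, read by CellTiter-Glo, with a stated time of 72 h; on this read-out lower numbers stand for stronger inhibition and higher numbers for weaker inhibition:
Compound 1, `CO[C@H]1C[C@H](C)CC2=C(N3CCC3)C(=O)C=C(NC(=O)/C(C)=C/C=C\[C@H](OC)[C@@H](OC(N)=O)/C(C)=C/[C@H](C)C1=O)C2=O`: 260 nM
Compound 2, `CO[C@H]1C[C@H](C)CC2=C(NCCN(C)C)C(=O)C=C(NC(=O)/C(C)=C/C=C\[C@H](OC)[C@@H](OC(N)=O)/C(C)=C/[C@H](C)/C1=N\OCC(=O)O)C2=O`: 2700 nM
Compound 3, `CO[C@H]1C[C@H](C)CC2=C(NCCN(C)C)C(=O)C=C(NC(=O)/C(C)=C/C=C\[C@H](OC)[C@@H](OC(N)=O)/C(C)=C/[C@H](C)/C1=N\O)C2=O`: 95 nM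

Compound 3 gives the lowest number of the three in this assay; compound 1 lies nearest to it and compound 2 furthest, both gaps beyond the scatter. Among the measured compounds shown here, the one step that changes the group on the oxime oxygen is a 28-fold lower number from compound 2 to compound 3 (1.45 log units; beyond the scatter), a large move towards stronger inhibition when the oxygen carries hydrogen rather than carboxymethyl.

Compound 4, `C=CCO/N=C1/[C@@H](OC)C[C@H](C)CC2=C(NCCN(C)C)C(=O)C=C(NC(=O)/C(C)=C/C=C\[C@H](OC)[C@@H](OC(N)=O)/C(C)=C/[C@@H]1C)C2=O`, is not yet measured in this assay. It differs from compound 3 in one place: allyl in place of hydrogen on an oxygen. For the measured compounds named here, the only measured step at this oxygen runs the other way and puts a different group there, so it gives a direction to guard against rather than a size to copy: the single precedent for a substituent on this oxygen raised the number sharply, but allyl is not carboxymethyl, and nothing measured tells how allyl itself behaves here. A moderate rise in the number is therefore expected, smaller than the step seen, with wide uncertainty: a 2.3-fold higher number from compound 3 to compound 4 (0.36 log units; beyond the scatter). On that basis compound 4 is expected to give about 220 nM in this assay, with a likely range from 70 nM to 700 nM.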

Compound 4, half-maximal inhibitory concentration: 400 nM
For compound 4 the middle estimate is 1.8-fold (0.26 log units) below the measured one; low and high end bracket the measured number.
By their numbers in this assay, from the lowest: compound 3; then compounds 1 and 4 (each within the scatter of the next); then compound 2.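

Hydroxy to allyloxy on the oxime oxygen in this assay gives a 4.2-fold higher number from compound 3 to compound 4 (0.62 log units; beyond the scatter) and so, unlike the earlier step, shows a cost from a substituent on this oxygen that carries no carboxy group. Vinyl in place of carboxy at the chain end gives a 6.8-fold lower number from compound 2 to compound 4 (0.83 log units; beyond the scatter) and thereby separates the two substituted oximes, so the high number of compound 2 does not follow from substitution on this oxygen alone; across these three compounds, the order from the lowest number is hydroxy, allyloxy, then the carboxymethyl ether, and none of them goes against it. Nothing at hand explains that order.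

Going by these compounds, whether a methyl group or a longer saturated chain on this oxygen tracks with allyl remains open, as does whether an amine at the chain end sits nearer allyl or the carboxylic acid. Also open, on these data alone, is whether the same order holds with a group other than the dimethylaminoethylamino substituent on the shared core.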